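From cyano to a 4-hydroxybut-1-yn-1-yl group

A few compounds are considered here, and "the series" means these few. Any claim that something is new, unique, unknown or untested is made for them only; others in the source may bear on it.

In an ADME assay on L1210/0 cells (Mus musculus) for cytotoxicity, with a stated time of 48 h (a higher number here means a weaker inhibitor, a lower number a stronger inhibitor), compound 3 `N#Cc1cn([C@H]2C[C@H](O)[C@@H](CO)O2)c(=O)[nH]c1=O` reads > 200000 nM as a limit of the assay and not as a number.

Two relatives on the same core do give numbers: compound 1 `O=c1[nH]c(=O)n([C@H]2C[C@H](O)[C@@H](CO)O2)cc1/C=N/O` gives 15500 nM and compound 2 `O=c1[nH]c(=O)n([C@H]2C[C@H](O)[C@@H](CO)O2)cc1/C=C/I` gives 63900 nM on the same scale.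

The next structure is compound 4 `O=c1[nH]c(=O)n([C@H]2C[C@H](O)[C@@H](CO)O2)cc1C#CCCO` and the change is 4-hydroxybut-1-yn-1-yl in place of cyano on an aromatic carbon with 4-hydroxybut-1-yn-1-yl in place of cyano on an aromatic carbon.

Three measured steps swap the group at this same carbon. The first, a 4.1-fold higher number from compound 1 to compound 2 (0.62 log units; beyond the scatter), is modest. The second, an at least 12-fold higher number from compound 1 to compound 3 (1.11 log units; beyond the scatter), is large. The third, an at least 3.1-fold higher number from compound 2 to compound 3 (0.49 log units; beyond the scatter), is at least modest. In both steps that end at compound 3 the cyano group gives the higher number, so leaving cyano should bring the number down, though compound 4 may still reach the limit.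

The expected change is an at least 2.5-fold lower number from compound 3 to compound 4 (0.39 log units; beyond the scatter) in this assay as an estimate of modest size.

For compound 4 the estimated value is 80000 nM with an expected range from 25000 nM to 190000 nM in this assay as the likely outcome.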

Compound 4, half-maximal inhibitory concentration: > 200000 nM
Compound 4: no number, only a limit (the forecaster's own chance of this, stated with the estimate: 40%); middle value at least 2.5-fold (0.39 log units) away from the limit.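

Swapping cyano for 4-hydroxybut-1-yn-1-yl does not bring a readable number in this assay: compound 4, like compound 3, gives a limit and not a number. Compound 4 therefore stands clearly apart from the two compounds with numbers, with an at least 3.1-fold higher number from compound 2 to compound 4 (0.49 log units; beyond the scatter) and an at least 12-fold higher number from compound 1 to compound 4 (1.11 log units; beyond the scatter), and among these four compounds both groups holding a triple bond end at the limit, while the two without one give numbers. The step between compound 3 and compound 4 cannot be read, since both sit at the same ceiling: the limit of > 200000 nM in this assay, at which 2 of the 4 values shown sit.

Which of compound 3 and compound 4 is the weaker stays open. So does whether an amine at the end of the chain, or the same chain with a double bond in place of the triple bond, would give a number.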